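Sulfonyl substituent change from compound 3 to compound 4

The source may report more compounds than this note shows. Statements on the series, on what has been measured and on what is new or still open speak of the compounds shown alone.

Among the measured compounds shown here, in a functional assay (Platelet, plasma) for inhibition, with Homo sapiens as the target (a higher number here means a weaker inhibitor, a lower number a stronger inhibitor), compound 3 `N#Cc1ccc(CS(=O)(=O)NC(=O)C2CCN(c3nc4c(cc3C#N)C(=O)OC4)CC2)cc1` gives 8900 nM, the lowest number measured so far. Compound 2 `CC1(C(=O)NS(=O)(=O)Cc2ccc(F)cc2)CCN(c2nc3c(cc2C#N)C(=O)OC3)CC1` gives 35400 nM, a higher number than compound 3, and the gap lies beyond the scatter. Compound 1 `N#Cc1cc2c(nc1N1CCC(C(=O)NS(=O)(=O)Cc3ccccc3)C1)COC2=O` reads > 300000 nM, which is a limit of the assay and not a number. Compound 4 `N#Cc1cc2c(nc1N1CCC(C(=O)NS(=O)(=O)C3(c4ccccc4)CC3)CC1)COC2=O` is next, with 1-phenylcyclopropyl in place of 4-cyanobenzyl on a sulfonyl sulfur. For the measured compounds named here, no measured pair isolates this change. A small rise in the number in this assay is expected, possibly none beyond the scatter. The estimated change is a 1.3-fold higher number from compound 3 to compound 4 (0.13 log units; within the scatter). For compound 4 the expected value is 12000 nM, with an estimated range of 3000 nM to 50000 nM.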

Compound 4, half-maximal inhibitory concentration: 4100 nM
Beside the measured number, compound 4's estimate is 2.9-fold (0.47 log units) above it; the range from low to high includes it.
By their numbers in this assay, from the lowest: compound 4; then compound 3; then compound 2. At a limit, above all of these: compound 1.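

In this assay, 1-phenylcyclopropyl on the sulfonyl sulfur reads better than 4-cyanobenzyl: a 2.2-fold lower number from compound 3 to compound 4 (0.34 log units; beyond the scatter). Among the compounds shown here, this is the first pair that differs in one place, and it shows that the nitrile of 4-cyanobenzyl is not required for a low number at this position. No measurement shown accounts for the step.

The change adds the three-membered ring and removes the nitrile together, so the contribution of each cannot be separated. On these data alone, how a 1-phenylcyclobutyl group or a simple cyclopropyl on the sulfonyl sulfur would read also remains open.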